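Methylamino nucleosides: heteroaryl swap at the five-membered ring

This account rests on a few compounds, and the source may have more. Where it says the series, first, only, none or still open, it means among the compounds named here.

Measured so far in a functional assay on K562 cells (Homo sapiens), read by MTT assay, with a stated time of 72 h; a higher number here means a weaker inhibitor, a lower number a stronger inhibitor:
compound 1 `CNc1ncnc2c1c(-c1ccsc1)cn2[C@@H]1O[C@H](CO)[C@@H](O)[C@H]1O`: > 20000 nM
compound 2 `Cc1ncnc2c1c(-c1ccsc1)cn2[C@@H]1O[C@H](CO)[C@@H](O)[C@H]1O`: 320 nM

Compound 1 sits at the limit of this assay, (the limit of > 20000 nM in this assay, at which 1 of the 2 values shown sits), so only a bound is known for it. The step of an at least 62-fold lower number from compound 1 to compound 2 (1.79 log units; beyond the scatter) concerns methyl in place of methylamino and does not touch the heteroaryl group.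

Compound 3 `CNc1ncnc2c1c(-c1ccco1)cn2[C@@H]1O[C@H](CO)[C@@H](O)[C@H]1O` differs from compound 1 by furan-2-yl in place of thiophen-3-yl on an aromatic carbon. Among the measured compounds shown here, no measured step bears on this change, so no step beyond the scatter is expected in this assay. Compound 3 is therefore estimated to remain near the limit, 20000 nM (range 5000 nM to 80000 nM), which implies the expected step of a number no higher from compound 1 to compound 3 (the limit leaves the size open).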

Compound 3, half-maximal inhibitory concentration: 220 nM
Compound 3: the middle estimate sits 91-fold (1.96 log units) above what was measured; measured number outside the range, below it.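

In this assay, the heteroaryl group on this aromatic carbon strongly affects the reading even with methylamino retained: an at least 90-fold lower number from compound 1 to compound 3 (1.95 log units; beyond the scatter). Among the compounds shown here, the earlier step changed only methylamino to methyl, so this is the first sign that furan-2-yl in place of thiophen-3-yl matters here. Compound 1 stands at a limit of the assay, so the size of this step remains open-ended: the limit of > 20000 nM in this assay, at which 1 of the 3 values shown sits.

Thiophen-2-yl or furan-3-yl at this carbon would separate the hetero atom from the point of attachment. Also open, on these data alone, is how furan-2-yl behaves with methyl in place of methylamino.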